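The source may hold more compounds than are shown below. What is called first, only, known or untested is meant among the compounds shown, and "the series" means these compounds.

Compound 1 `Nc1cc(Cl)c(Cl)cc1C1=NN(C(=O)c2ccccc2)CC1` gives 36.1% in an assay on isolated protein for inhibition of Nitric oxide synthase, inducible (Homo sapiens), with a stated time of 30 min, tested at 1 mM; on this read-out lower numbers stand for less inhibition and higher numbers for more inhibition at the one concentration tested (going by the name of the read-out). Compound 2 `Nc1cc(Cl)c(Cl)cc1C1=NN(C(=O)CCc2ccccc2)CC1` gives 50.2% in this assay. The change between the two is phenethyl in place of phenyl on a carbonyl carbon, and it made the step of a number 14.1 percentage points higher from compound 1 to compound 2 (beyond the scatter).

Compound 3 `COc1cc(N)c(C2=NN(C(=O)c3ccccc3)CC2)cc1OC` gives 28.9% in this assay. It carries a different core from compound 1; the difference between the two cores is not broken down here. The values of compound 3 and compound 1 lie within the scatter of each other, while the value of compound 3 lies beyond the scatter below that of compound 2.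

Compound 4 `COc1cc(N)c(C2=NN(C(=O)CCc3ccccc3)CC2)cc1OC` has not yet been measured. It differs from compound 3 by phenethyl in place of phenyl on a carbonyl carbon, which is the same change, at the same kind of place, as that from compound 1 to compound 2. For the measured compounds named here, the only guide to its effect on the second core is the single step of the first core, so the expectation rests on one pair alone. A step of similar size is expected, namely a number 14.1 percentage points higher from compound 3 to compound 4 (beyond the scatter), because compound 1 to compound 2 showed a number 14.1 percentage points higher from compound 1 to compound 2 (beyond the scatter). Compound 4 is therefore estimated at 43%, with a range from 30% to 56%.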

Compound 4, a percentage reported as inhibition, at one concentration (the size of the read-out at that concentration, not a potency): 23.7%
Compound 4: the middle estimate sits 19.3 percentage points above what was measured, outside the stated range (below it).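

In this assay, phenethyl in place of phenyl on a carbonyl carbon gives a number 5.2 percentage points lower from compound 3 to compound 4 (within the scatter), so the rise seen on the other core does not reappear here. The change therefore cannot be carried between these two cores as a fixed increment: the same change on two cores in this assay, a number 14.1 percentage points higher (beyond the scatter) from compound 1 to compound 2 and a number 5.2 percentage points lower (within the scatter) from compound 3 to compound 4, 19.3 percentage points apart, beyond the scatter of two such steps

This rests on a single pair per core, and it does not show which feature of the cores separates the two steps, nor does it establish that phenethyl lowers the number on the core of compound 3, since that step lies within the scatter.

Still open, from the compounds shown here alone, is whether a longer chain on the carbonyl carbon, or an amine in place of the phenyl or phenethyl group, would follow the behaviour of the core of compound 1 or that of compound 3. Also open, going by these compounds, is how the same change would behave on a core carrying one chloro and one methoxy group.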